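The source may hold more compounds than are shown below. What is called first, only, known or untested is meant among the compounds shown, and "the series" means these compounds.

In an ADME assay on microsomes from liver (Rattus norvegicus) for metabolic stability (on this read-out higher numbers stand for fast clearance and lower numbers for slow clearance), compound 1 `N#Cc1ccccc1Oc1ccc([C@H]2CC[C@@H](C(N)=O)N2)cc1` gives 1.8 mL.min-1.g-1 and compound 2 `NC(=O)[C@@H]1CC[C@H](c2cccc(Oc3ccccc3)c2)N1` gives 4 mL.min-1.g-1 while compound 3 `NC(=O)[C@@H]1CC[C@H](c2ccc(Oc3ccccc3)cc2)N1` gives 1.9 mL.min-1.g-1 on the same read-out. Compound 3 thus stands within the scatter of compound 1 and shows a lower number than compound 2, with that gap beyond the scatter.

Compound 4 `NC(=O)[C@@H]1CC[C@H](c2ccc(Oc3ccc(F)cc3)cc2)N1` carries fluoro in place of hydrogen on an aromatic carbon, para to a large group, as counted in fluoro in place of hydrogen on an aromatic carbon against compound 3. Within the data shown here, the one measured step at an aromatic carbon is a 1.1-fold higher number from compound 1 to compound 3 (0.02 log units; within the scatter) and it exchanges hydrogen for cyano without leaving the scatter. Among the measured compounds shown here, no measured step involves fluoro, so this step bears on the change only loosely. In this assay no change beyond the scatter is therefore expected, and these data give no firm direction. The expected step is a 1.1-fold lower number from compound 3 to compound 4 (0.05 log units; within the scatter) and stays within the scatter. Compound 4 is estimated at 1.7 mL.min-1.g-1 with 0.9 mL.min-1.g-1 to 3.4 mL.min-1.g-1 as the expected range.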

Compound 4, intrinsic clearance in microsomes: 2 mL.min-1.g-1
Estimate against measurement, compound 4: 1.2-fold (0.07 log units) below, within the range that was stated.
By their numbers in this assay, from the lowest: compounds 1, 3, 4 and 2 (each within the scatter of the next, the first and the last beyond it).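

In this assay, among these compounds, phenyl to 4-fluorophenyl gives a 1.1-fold higher number from compound 3 to compound 4 (0.02 log units; within the scatter), the first measured step that involves fluoro and the first at this position, para to a large group. Together with a 1.1-fold higher number from compound 1 to compound 3 (0.02 log units; within the scatter), it makes two measured changes on an aromatic carbon, one with nitrile and one with fluoro, and both stay within the scatter; no compound shown goes against this. No measurement shown offers an explanation for the size of this step.

On these data alone, whether a methoxy group, an amine or a carboxylic acid at the same position would take this assay beyond the scatter remains open. As far as these compounds go, it also remains open whether fluoro would give a similarly small step on an aromatic carbon of compound 2.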